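A few compounds are considered here, and "the series" means these few. Any claim that something is new, unique, unknown or untested is made for them only; others in the source may bear on it.

Compound 3 `Cc1ccc(CN(Cc2ccc(C(=O)NO)cc2)S(=O)(=O)c2c(F)c(F)c(F)c(F)c2F)cc1` gives 101 nM in an assay on isolated protein for inhibition of histone deacetylase 8 (Homo sapiens), read by mobility shift assay (on this read-out lower numbers stand for stronger inhibition and higher numbers for weaker inhibition), the lowest of the two numbers shown; compound 1 `O=C(NO)c1ccc(CN(Cc2ccccc2)S(=O)(=O)c2c(F)c(F)c(F)c(F)c2F)cc1` gives 150 nM in this assay, and the two lie within the scatter of each other. For compound 2 `CN(C)c1ccc(CN(Cc2ccc(C(=O)NO)cc2)S(=O)(=O)c2c(F)c(F)c(F)c(F)c2F)cc1` this assay reports only a limit, > 1000 nM. The change from compound 3 to compound 4 `CC(C)(C)c1ccc(CN(Cc2ccc(C(=O)NO)cc2)S(=O)(=O)c2c(F)c(F)c(F)c(F)c2F)cc1` is tert-butyl in place of methyl on an aromatic carbon. For the measured compounds named here, the steps that bear on it are a 1.5-fold lower number from compound 1 to compound 3 (0.17 log units; within the scatter) and an at least 6.6-fold higher number from compound 1 to compound 2 (0.82 log units; beyond the scatter), the latter resting on (the limit of > 1000 nM in this assay, at which 1 of the 3 values shown sits); an at least 9.9-fold lower number from compound 2 to compound 3 (0.99 log units; beyond the scatter) runs the other way. Going by the values given here, a larger alkyl group at this position has no measured counterpart, so a drift toward the weaker side, possibly beyond the scatter, is the expectation but not a firm one. Compound 4 is expected to give 220 nM, between 80 nM and 700 nM, an estimated step of a 2.2-fold higher number from compound 3 to compound 4 (0.34 log units; beyond the scatter).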

Compound 4, half-maximal inhibitory concentration: 68 nM
The estimate for compound 4 lay 3.2-fold (0.51 log units) above the measured number, outside the stated range (below it).
By their numbers in this assay, from the lowest: compounds 4, 3 and 1 (each within the scatter of the next, the first and the last beyond it). At a limit, above all of these: compound 2.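

Going from methyl to tert-butyl on this aromatic carbon leaves this assay without a change beyond the scatter, with a 1.5-fold lower number from compound 3 to compound 4 (0.17 log units; within the scatter). Hydrogen to tert-butyl is the first change at this position to give a step beyond the scatter toward lower numbers, a 2.2-fold lower number from compound 1 to compound 4 (0.34 log units; beyond the scatter). The dimethylamino compound stays well apart, with an at least 14-fold lower number from compound 2 to compound 4 (1.16 log units; beyond the scatter), and the size of that step rests on a limit: the limit of > 1000 nM in this assay, at which 1 of the 4 values shown sits.

Still open, going by these compounds, is whether a methoxy group, a primary amine or a carboxylic acid here would track dimethylamino or the alkyl groups. Also open, on these data alone, is whether a longer chain or a phenyl group at this position would be accepted as tert-butyl is.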